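The source may hold more compounds than are shown below. What is called first, only, known or untested is meant among the compounds shown, and "the series" means these compounds.

Compound 1, with the structure `N[C@H]1CC[C@H](Nc2c(C(=O)NCc3ccccn3)nc(Br)c3cccnc23)CC1`, is the starting point of this account, but in a functional assay on SK-BR-3 cells (Homo sapiens) for cytotoxicity, read by MTT assay, with a stated time of 72 h (a lower number here means a stronger inhibitor, a higher number a weaker inhibitor), compound 1 stands at "not determined" (no result reported), so no result was reported for it there. The same is true of compound 2, the structure `NCCCNc1c(C(=O)NCc2ccc(F)cc2)nc(Br)c2cccnc12`, for which this assay also gives compound 2 only "not determined" (no result reported). Going by the values given here, the only measured compound in the set is compound 3, the structure `N[C@H]1CC[C@H](Nc2c(C(=O)NCc3ccc(F)cc3)nc(N3CCCCS3(=O)=O)c3cccnc23)CC1`, which in this assay gives 8500 nM. Compound 4, the structure `C[C@H](NC(=O)c1nc(Br)c2cccnc2c1N[C@H]1CC[C@H](N)CC1)c1ccc(F)cc1`, has not yet been measured. It differs from compound 1 by 1-(4-fluorophenyl)ethyl in place of (pyridin-2-yl)methyl on an amide-type nitrogen, so the change sits on the amide-type nitrogen whose other neighbour is the carbonyl carbon. With no measured step between any two of these compounds, the size and direction of the move from compound 1 to compound 4 in this assay cannot be read from the data, and the only anchor is the value of compound 3. On that basis compound 4 is expected to give about 6000 nM, estimated to lie between 1200 nM and 30000 nM.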

Compound 4, half-maximal inhibitory concentration: 9000 nM
For compound 4 the middle estimate is 1.5-fold (0.18 log units) below the measured one, and the stated range covers the measured number.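

In this assay, going by these compounds alone, compound 1 stands at "not determined" (no result reported), so no step from compound 1 to compound 4 can be read. The compounds shown leave open how (pyridin-2-yl)methyl and 1-(4-fluorophenyl)ethyl compare on the shared core. No data shown here explain the value of compound 4.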